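The source may report more compounds than this note shows. Statements on the series, on what has been measured and on what is new or still open speak of the compounds shown alone.

Measured compounds in the series:
- compound 1 `CC(=O)c1cccc(Nc2nc(-c3sc(NC(=O)NCc4ccc(Cl)cc4)nc3C)cs2)c1`: in an ADME assay on RD cells (Homo sapiens) for cytotoxicity, read by microscopy (on this read-out higher numbers stand for lower toxicity in this test and lower numbers for higher toxicity in this test), compound 1 gives "not determined" (no result reported)
- compound 2 `CC(=O)c1cccc(Nc2nc(-c3sc(NC(=O)C(C)(C)C)nc3C)cs2)c1`: in this assay compound 2 gives 8830 nM
- compound 3 `CC(=O)c1cccc(Nc2nc(-c3sc(NC(=S)NC4CCCCC4)nc3C)cs2)c1`: in this assay compound 3 gives "not determined" (no result reported)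

Compound 3 stands without a single number in this assay; one further entry in the series, compound 1, likewise has no number. The only measured point for the shared core is therefore compound 2, whose value in this assay is 8830 nM.

The step from compound 3 to compound 4 `CC(=O)c1cccc(Nc2nc(-c3sc(NC(=O)c4ccccc4)nc3C)cs2)c1` is a group of 8 heavy atoms (7 carbon, 1 oxygen; one six-membered aromatic ring of carbon only) in place of a group of 9 heavy atoms (7 carbon, 1 nitrogen, 1 sulfur; one six-membered non-aromatic ring of carbon only), on a nitrogen on an aromatic ring. For the measured compounds named here, no measured pair shows what such a change does in this assay, and compound 3 itself has no number, so the step cannot be sized from data; the size of the step is unknown and no direction beyond the scatter can be claimed. What can be said is that the shared core with a short acyl group on that nitrogen, compound 2, sits in the micromolar range in this assay.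

On that basis compound 4 is expected to give about 8000 nM in this assay, with an estimated range from 2500 nM to 30000 nM.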

Compound 4, half-maximal cytotoxic concentration: 11800 nM
For compound 4 the middle estimate is 1.5-fold (0.17 log units) below the measured one; the measured number falls inside the stated range.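

In this assay, the series gains its first readable pair differing in one place: phenyl in place of tert-butyl on a carbonyl carbon gives a 1.3-fold higher number from compound 2 to compound 4 (0.13 log units; within the scatter) and so does not separate the two acyl groups on this read-out. On a nitrogen on an aromatic ring, benzoyl and the tert-butyl carbonyl group of compound 2 therefore stand level, which means that for these two compounds, replacing a non-ring branched group with an aromatic ring on the carbonyl carbon brings no change that can be told from the usual scatter. Nothing at hand bears on why the two compounds stand level in this test.

Steps that involve compound 1 or compound 3 cannot be read, as neither compound has a single number, so the urea and thiourea groups on this nitrogen remain unplaced against the two amides. The compounds shown also leave open whether the same level holds with a carboxylic acid or an amine on the phenyl ring of benzoyl, or with a longer alkyl chain in place of tert-butyl on the carbonyl carbon.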